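The compounds below may be only part of what the source reports. "The series", "measured", "known", "first", "only" and "open" are said of these compounds alone.

Measured compounds:
compound 1 `Cc1ccc(OCC(=O)N(Cc2cccs2)c2cccnc2)cc1`, 198 nM
compound 2 `CCN(Cc1cccs1)C(=O)COc1ccc(C(F)(F)F)cc1`, 236 nM
compound 3 `CCN(Cc1cccs1)C(=O)COc1ccc2c(c1)CCC2`, 0.8 nM

In an assay on HEK293 cells for agonist activity at transient receptor potential cation channel subfamily M member 8 (Homo sapiens), read by fluorescence and calcium flux, with a stated time of 15 min (on this read-out lower numbers stand for an effect already at smaller amounts and higher numbers for an effect only at larger amounts of compound), compound 1 gives 198 nM, which is the second highest of the three numbers. Compound 2 gives 236 nM, and the two values lie within the scatter of each other, so nothing separates them. Compound 3 gives 0.8 nM, a far lower number that stands beyond the scatter from both. Compound 3 and compound 2 both carry an ethyl on the amide-type nitrogen, while compound 1 carries a pyridin-3-yl there; the three compounds also differ in the aryl ether part, so no single step between measured compounds is shown.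

Compound 4 `CCCN(Cc1cccs1)C(=O)COc1ccc(C)cc1` has not yet been measured. It differs from compound 1 in one place: propyl in place of pyridin-3-yl on an amide-type nitrogen. The measured set shows that an alkyl group on that nitrogen is compatible with a very low number, as compound 3 gives 0.8 nM, but it also shows that compound 2 with such an alkyl gives 236 nM, so the aryl ether part clearly matters too.

On this basis compound 4 is expected to fall toward a lower number than compound 1, a moderate step of a 3.3-fold lower number from compound 1 to compound 4 (0.52 log units; beyond the scatter), with wide uncertainty. The estimate for compound 4 is 60 nM, with a range from 10 nM to 400 nM.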

Compound 4, half-maximal effective concentration: 40 nM
Estimate against measurement, compound 4: 1.5-fold (0.18 log units) above; the measured number falls inside the stated range.
By their numbers in this assay, from the lowest: compound 3; then compound 4; then compounds 1 and 2 (each within the scatter of the next).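

In this assay, among the compounds shown here, the step of a 5.0-fold lower number from compound 1 to compound 4 (0.69 log units; beyond the scatter) is the first to change the group on the amide-type nitrogen while the rest of the compound stays the same, and it lies beyond the scatter. It shows that, with the remainder of compound 1 held fixed, this position does not need an aromatic ring: propyl, with no ring and no hydrogen-bond acceptor, gives a lower number than pyridin-3-yl, a six-membered aromatic ring with 1 hetero atom. No information at hand accounts for this difference, so the step stands as an observation only.

For the compounds shown here, the single pair cannot separate the loss of the ring from the loss of its nitrogen, and a plain phenyl on this nitrogen would be needed to tell these apart. Also open, on these data alone, is how far the number follows the chain on this nitrogen, as with a butyl or a cyclopropyl, and whether the same exchange gives a step of similar size when the aryl ether part of the core is different.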